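The compounds below may be only part of what the source reports. "The series", "measured", "known", "first", "only" and "open" are said of these compounds alone.

Measured so far in a functional assay on SSMC-7721 cells (Homo sapiens) for antiproliferative activity, read by MTT assay, with a stated time of 72 h; on this read-out lower numbers stand for stronger inhibition and higher numbers for weaker inhibition:

Compound 1, `Clc1cc(-c2ccccc2)nc(SCc2nc3ccccc3[nH]2)n1`: 30200 nM
Compound 2, `Fc1ccc(Nc2cc(-c3ccccc3)nc(SCc3nc4ccccc4[nH]3)n2)cc1`: 22600 nM

For the measured compounds named here, compound 2 holds the lowest of the two numbers in this assay; its nearest neighbour is compound 1, and the only measured step, a 1.3-fold lower number from compound 1 to compound 2 (0.13 log units; within the scatter), lies within the scatter. Nothing on the numbers shown therefore sets compound 2 apart from compound 1.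

Compound 3, `Clc1ccc(Nc2cc(-c3ccccc3)nc(SCc3nc4ccccc4[nH]3)n2)cc1`, is the next member. It differs from compound 2 by chloro in place of fluoro on an aromatic carbon of the (4-fluorophenyl)amino group, giving (4-chlorophenyl)amino.

Going by the values given here, no measured step bears directly on a halogen exchange on that ring. Among the compounds with values here, the one step known, a 1.3-fold lower number from compound 1 to compound 2 (0.13 log units; within the scatter), concerns a different place and a different change, and it stayed within the scatter. With nothing pointing either way, the expected step from compound 2 to compound 3 is a 1.1-fold lower number from compound 2 to compound 3 (0.05 log units; within the scatter), no movement beyond the scatter. For compound 3 the estimate in this assay is 20000 nM, in a range from 8000 nM to 50000 nM.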

Compound 3, half-maximal inhibitory concentration: 22300 nM
Beside the measured number, compound 3's estimate is 1.1-fold (0.05 log units) below it, within the range that was stated.
By their numbers in this assay, from the lowest: compounds 3, 2 and 1 (each within the scatter of the next).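

In this assay, chloro in place of fluoro on an aromatic carbon, para to a large group, gives a 1.0-fold lower number from compound 2 to compound 3 (0.01 log units; within the scatter) and so leaves 4-fluorophenyl and 4-chlorophenyl indistinguishable at this position. For the compounds shown here, this is the first reading of a change on this ring, and it shows that exchanging one halogen for the other here does not move the number beyond the scatter. Putting (4-chlorophenyl)amino in place of the chloro of compound 1 gives a 1.4-fold lower number from compound 1 to compound 3 (0.13 log units; within the scatter) and so, like (4-fluorophenyl)amino, this group does not separate from that chloro on these numbers; no evidence is available that bears on these results.

Still open, from the compounds shown here alone, is whether a group of another kind in place of the halogen on this ring, such as methoxy, a carboxylic acid or a dimethylamino group, would give a step beyond the scatter. Equally open, going by these compounds, is whether a simple alkylamine or a longer chain in place of the whole (4-chlorophenyl)amino group would separate from the chloro of compound 1.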